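Three selenium compounds and a benzyl analogue awaiting a cytotoxicity number

The source may report more compounds than this note shows. Statements on the series, on what has been measured and on what is new or still open speak of the compounds shown alone.

Measured so far:
- compound 1, `C[Se]/C(=N\C(=O)c1cccs1)NC(=O)c1cccs1`, gives 41100 nM in an ADME assay on MCF-10A cells (Homo sapiens) for cytotoxicity, read by MTT assay, with a stated time of 72 h; a lower number here means a stronger inhibitor of growth, a higher number a weaker inhibitor of growth
- compound 2, `O=C(/N=C(/NC(=O)c1csc([N+](=O)[O-])c1)[Se]Cc1ccccc1)c1csc([N+](=O)[O-])c1`, gives 54100 nM in this assay
- compound 3, `C[Se]/C(=N\C(=O)c1cc(-c2ccccc2)nc2ccccc12)NC(=O)c1cc(-c2ccccc2)nc2ccccc12`, gives 20100 nM in this assay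

Compound 1 stands second highest of the three numbers. Its nearest neighbour is compound 2, whose value lies within the scatter of repeated measurements, so the two cannot be ranked against each other. Compound 3 gives the lowest number, and its gap to compound 1 lies beyond the scatter, so compound 3 is the stronger growth inhibitor of that pair.

The unmeasured compound 4, `O=C(/N=C(/NC(=O)c1cccs1)[Se]Cc1ccccc1)c1cccs1`, keeps the thiophene amide arms of compound 1 and alters only the group on selenium. The change is phenyl in place of hydrogen on a saturated chain carbon bound to a selenium atom; cut one bond further out, it reads methyl to benzyl. For the measured compounds named here, no pair of measured compounds differs by this change alone, so nothing directly indicates its effect, and the three values as a whole sit in a narrow band.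

The step of a 1.1-fold higher number from compound 1 to compound 4 (0.04 log units; within the scatter) is expected to be small, not beyond the scatter. Compound 4 is estimated at 45000 nM, in the range 20000 nM to 100000 nM.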

Compound 4, concentration for total growth inhibition: > 100000 nM
Compound 4: a limit, no number; the forecaster's own chance of this, stated with the estimate: 15%; at least 2.2-fold (0.34 log units) between middle value and limit.
By their numbers in this assay, from the lowest: compound 3; then compounds 1 and 2 (each within the scatter of the next). At a limit, above all of these: compound 4.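

Phenyl in place of hydrogen on a saturated chain carbon bound to a selenium atom, which reads as methyl to benzyl, gives an at least 2.4-fold higher number from compound 1 to compound 4 (0.38 log units; beyond the scatter). The group on selenium therefore matters: with the thiophene amide arms unchanged, this one change weakens growth inhibition in this assay by more than the scatter of repeated measurements. Compound 4 gives > 100000 nM, which is a limit of the assay and not a number, so the true size of the step stays unknown, and the reading rests on this one limit: the limit of > 100000 nM in this assay, at which 1 of the 4 values shown sits.

From the compounds shown here alone, whether ethyl, a longer chain, or a chain ending in an amine or a carboxylic acid on selenium would behave like methyl or like benzyl remains open. Also open, going by these compounds, is whether methyl to benzyl has the same effect with other amide arms.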